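This account rests on a few compounds, and the source may have more. Where it says the series, first, only, none or still open, it means among the compounds named here.

Among the measured compounds shown here, in a functional assay on T-24 cells (Homo sapiens) for antiproliferative activity, read by MTT assay, with a stated time of 48 h (on this read-out lower numbers stand for stronger inhibition and higher numbers for weaker inhibition), compound 2 `O=C(Nc1cccc(Cl)c1)Nc1cccc(CNc2nccnc2Cl)c1` gives 6810 nM, the lowest number among the three compounds measured so far. Compound 1 `O=C(Nc1ccccc1)Nc1cccc(CNc2nccnc2Cl)c1`, with a plain phenyl in place of 3-chlorophenyl, gives 19800 nM. Compound 3 `O=C(Nc1cccc(CNc2nccnc2Cl)c1)NC1CCCC1` gives > 40000 nM, which is a limit of the assay and not a number.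

The next compound, compound 4 `CCc1ccccc1NC(=O)Nc1cccc(CNc2nccnc2Cl)c1`, has 2-ethylphenyl in place of 3-chlorophenyl on an amide-type nitrogen. For the measured compounds named here, two measured steps bear on this change. Putting chloro in place of hydrogen on an aromatic carbon gave a 2.9-fold lower number from compound 1 to compound 2 (0.46 log units; beyond the scatter), while replacing 3-chlorophenyl with cyclopentyl gave an at least 5.8-fold higher number from compound 2 to compound 3 (0.76 log units; beyond the scatter). Compound 4 keeps an aromatic ring but loses the chlorine, so it is expected to sit closer to compound 1 at 19800 nM than to compound 2. Going by the values given here, no measured compound carries an ethyl group, which makes this expectation uncertain. The expected result is a modest rise, a 2.1-fold higher number from compound 2 to compound 4 (0.31 log units; beyond the scatter). For compound 4, the estimated value is 14000 nM, with an expected range from 5000 nM to 38000 nM.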

Compound 4, half-maximal inhibitory concentration: 8720 nM
Compound 4: the middle estimate sits 1.6-fold (0.21 log units) above what was measured, and the stated range covers the measured number.
By their numbers in this assay, from the lowest: compounds 2 and 4 (each within the scatter of the next); then compound 1. At a limit, above all of these: compound 3.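

In this assay, chloro is no longer the only group shown to lower the number from the plain phenyl: ethyl in place of hydrogen gives a 2.3-fold lower number from compound 1 to compound 4 (0.36 log units; beyond the scatter). Placing 2-ethylphenyl where 3-chlorophenyl stood gives a 1.3-fold higher number from compound 2 to compound 4 (0.11 log units; within the scatter), so this assay does not separate these two groups on the amide-type nitrogen, even though one carries chlorine and the other only carbon. Compound 3 is a limit and not a number, so the aromatic ring of compound 4 yields only a floor against it, an at least 4.5-fold lower number from compound 3 to compound 4 (0.66 log units; beyond the scatter), and that floor rests on a single capped value: the limit of > 40000 nM in this assay, at which 1 of the 4 values shown sits.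

The compounds shown leave open whether a longer chain, such as butyl, on that phenyl ring would keep the number at this level. They also leave open whether an amine or a carboxylic acid there would do the same.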